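The source may report more compounds than this note shows. Statements on the series, on what has been measured and on what is new or still open speak of the compounds shown alone.

Compound 1 `Cc1cc(C(=O)NC(C)C)nn1Cc1cc(Cl)ccc1OCc1ccccc1` — in a physicochemical assay for lipophilicity, at pH 7.4 (a higher number here means a more lipophilic compound, a lower number a more polar compound), compound 1 reaches only the limit of the measurement, > 3.7.
Compound 2 `Cc1cc(C(=O)Nc2ccccc2)nn1Cc1cc(Cl)ccc1OCc1ccccc1` — in this assay compound 2 likewise returns a limit, > 3.7.
Compound 3 `Cc1cc(C(=O)Nc2ccccn2)nn1Cc1cc(Cl)ccc1OCc1ccccc1` — in this assay compound 3 again returns a limit, > 3.7.

Compound 3 therefore stands at the ceiling of what this assay can report, and the two other values shown sit at the same ceiling, so the limit of > 3.7 in this assay, at which 3 of the 3 values shown sit, describes all three. Going by the values given here, none of the measured steps can be read for size: a step that the two limits leave unreadable from compound 1 to compound 2, a step that the two limits leave unreadable from compound 1 to compound 3 and a step that the two limits leave unreadable from compound 2 to compound 3 are all hidden by the limits, and nothing in them tells whether the change of the amide substituent moves the value at all.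

Compound 4 `Cc1cc(C(=O)NCc2cccnc2)nn1Cc1cc(Cl)ccc1OCc1ccccc1` has not yet been measured. Compared with compound 3 the change is (pyridin-3-yl)methyl in place of pyridin-2-yl on an amide-type nitrogen. Among the compounds with values here, the only bearing the measured steps have on this is that every variation of the group on the amide-type nitrogen so far has stayed at the limit; they give no size in either direction. The estimate is expressed as a step that the limit leaves unreadable from compound 3 to compound 4, with the expectation that compound 4 most likely also sits at or beyond the ceiling. Compound 4 is thus expected to give about 3.9, within 3.3 to 4.5.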

Compound 4, distribution coefficient: > 3.7
Compound 4 gave a limit, no number; the forecaster's own chance of this, stated with the estimate: 60%; the middle value lies beyond the limit too.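

In this assay compound 4 returns only a limit, so none of its steps from compound 1, compound 2 or compound 3 can be read for size, and the four compounds share a single reading: the limit of > 3.7 in this assay, at which 4 of the 4 values shown sit.

The compounds shown leave open how far each true value lies from that limit, and whether changing the group on the amide-type nitrogen moves the value at all.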